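The compounds below may be only part of what the source reports. "The series", "measured", "known", "first", "only" and "open" are said of these compounds alone.

Measured in a functional assay on HL-60 cells (Homo sapiens) for antiproliferative activity, with a stated time of 72 h; a higher number here means a weaker inhibitor, a lower number a stronger inhibitor:
- compound 1 `CCCC#Cc1cc([C@@H]2O[C@H](CO)[C@@H](O)[C@H]2O)n2ncnc(N)c12`: 200 nM
- compound 2 `Nc1ncnn2c([C@@H]3O[C@H](CO)[C@@H](O)[C@H]3O)cc(C#Cc3ccccc3)c12`: > 100000 nM
- compound 3 `Nc1ncnn2c([C@@H]3O[C@H](CO)[C@@H](O)[C@H]3O)cc(-c3ccc(F)cc3)c12`: 68300 nM

Compound 2 gives > 100000 nM, which is a limit of the assay and not a number. Of the two true numbers, compound 3 has the higher, 68300 nM. Compound 4 `Nc1ncnn2c([C@@H]3O[C@H](CO)[C@@H](O)[C@H]3O)cc(-c3ccoc3)c12` carries furan-3-yl in place of 4-fluorophenyl on an aromatic carbon. Among the measured compounds shown here, two measured steps bear on this change. One is large: a 340-fold higher number from compound 1 to compound 3 (2.53 log units; beyond the scatter). The other, an at least 1.4-fold lower number from compound 2 to compound 3 (0.16 log units; that floor lies within the scatter), has a floor within the scatter. Both compound 2 and compound 3 carry an aromatic ring in this substituent and sit far from compound 1, so furan-3-yl, also aromatic, is expected to stay in the weak range. A modest move to a lower number is expected, and the estimated step is a 6.8-fold lower number from compound 3 to compound 4 (0.83 log units; beyond the scatter). For compound 4 the estimated value is 10000 nM, with an expected range of 700 nM to 90000 nM.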

Compound 4, half-maximal inhibitory concentration: 500 nM
Compound 4: middle estimate off by 20-fold (1.30 log units), on the high side; measured number outside the range, below it.
By their numbers in this assay, from the lowest: compound 1; then compound 4; then compound 3. At a limit, above all of these: compound 2.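

Replacing the six-membered 4-fluorophenyl with the five-membered furan-3-yl gives a 140-fold lower number from compound 3 to compound 4 (2.14 log units; beyond the scatter) in this assay, so an aromatic ring on this carbon need not mean a weak compound. The step of an at least 200-fold lower number from compound 2 to compound 4 (2.30 log units; beyond the scatter) starts from a limit of the assay, not a number: the limit of > 100000 nM in this assay, at which 1 of the 4 values shown sits. Pent-1-yn-1-yl still keeps a small edge over furan-3-yl, with a 2.5-fold higher number from compound 1 to compound 4 (0.40 log units; beyond the scatter).

From the compounds shown here alone, it remains open whether the gain follows the smaller ring, its ring oxygen or both. A thiophen-3-yl or pyridin-3-yl ring could help separate these.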